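Replacing a methylpyrazole with an imidazole on a shared core

The compounds below may be only part of what the source reports. "The series", "measured", "known", "first", "only" and "open" are said of these compounds alone.

Of the compounds shown here, three with one shared core have been measured in a functional assay on CWR22R cells (Homo sapiens) for antiproliferative activity, read by CCK-8 assay, with a stated time of 6 days; a higher number here means a weaker inhibitor, a lower number a stronger inhibitor. Compound 1 `CCN(c1ccc(C#N)c(Cl)c1)c1cc(-n2cnc3ccccc32)ccc1C` gives 3040 nM. Compound 2 `CCN(c1ccc(C#N)c(Cl)c1)c1cc(-c2cncnc2)ccc1C` gives > 30000 nM, which is a limit of the assay and not a number. Compound 3 `CCN(c1ccc(C#N)c(Cl)c1)c1cc(-c2c[nH]nc2C)ccc1C` gives 5380 nM. The gap to its nearest neighbour is a 1.8-fold higher number from compound 1 to compound 3 (0.25 log units; within the scatter), so these two values cannot be told apart.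

Compound 4 `CCN(c1ccc(C#N)c(Cl)c1)c1cc(-n2ccnc2)ccc1C` changes one group of compound 3: 1H-imidazol-1-yl in place of 3-methyl-1H-pyrazol-4-yl on an aromatic carbon. The new 1H-imidazol-1-yl sits on an aromatic carbon, para to a methyl group.

The measured steps at this same place show that the group can matter. One is an at least 9.8-fold higher number from compound 1 to compound 2 (0.99 log units; beyond the scatter), and another is an at least 5.5-fold lower number from compound 2 to compound 3 (0.74 log units; beyond the scatter). Both involve pyrimidin-5-yl, a group that compound 4 does not carry. Compound 4 keeps a five-membered aromatic ring with 2 hetero atoms, as compound 3 does, so the more relevant comparison is the small step of a 1.8-fold higher number from compound 1 to compound 3 (0.25 log units; within the scatter). No change beyond the scatter is therefore expected. For compound 4, the expected step is a 1.1-fold higher number from compound 3 to compound 4 (0.05 log units; within the scatter). Compound 4 is estimated at 6000 nM, with an expected range from 2000 nM to 20000 nM.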

Compound 4, half-maximal inhibitory concentration: > 30000 nM
Compound 4: a limit, no number (the forecaster's own chance of this, stated with the estimate: 10%); middle value at least 5.0-fold (0.69 log units) away from the limit.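

Compound 4 shows that a five-membered aromatic ring with 2 hetero atoms is not enough at this position, since 1H-imidazol-1-yl in place of 3-methyl-1H-pyrazol-4-yl gives an at least 5.5-fold higher number from compound 3 to compound 4 (0.74 log units; beyond the scatter). Joining the group to the shared core through a ring nitrogen is not enough to keep the activity either, as compound 1 also has this kind of link, and the change to the smaller imidazole gives an at least 9.8-fold higher number from compound 1 to compound 4 (0.99 log units; beyond the scatter). Both steps give only a minimum size, and the step between compound 2 and compound 4 cannot be read, as both compounds stand at the same limit: the limit of > 30000 nM in this assay, at which 2 of the 4 values shown sit.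

The step from compound 3 to compound 4 changes the ring, its point of attachment, the methyl group and the count of hydrogen-bond donors all at once, so the compounds shown cannot separate these changes. As far as these compounds go, how an imidazol-1-yl ring carrying a methyl group, or a plain amine at this position, would read in this assay remains open.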